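Replacing the Acetyl Group of Compound 2

The source may report more compounds than this note shows. Statements on the series, on what has been measured and on what is new or still open speak of the compounds shown alone.

Compound 1 `O=C(CO[N+](=O)[O-])Nc1ccc(C(=O)/C=C/c2ccc(Cl)cc2)cc1` is tested in a functional assay on the whole organism (strain albino) for inhibition, with Rattus norvegicus as the target, read by paw edema, with stated times of 30 min and 1 h, at a dose of 100 mg/kg by the oral route (on this read-out lower numbers stand for less inhibition and higher numbers for more inhibition at the one dose given (going by the name of the read-out)), where compound 1 gives 42%. Compound 2 `CC(=O)c1ccc(OCC(=O)Nc2ccc(C(=O)/C=C/c3ccc(Cl)cc3)cc2)cc1` differs by carrying 4-acetylphenyl in place of nitro on an oxygen on a saturated carbon, and in this assay compound 2 gives 43%; the step of a number 1 percentage points higher from compound 1 to compound 2 (within the scatter) lies within the scatter. On these two numbers compound 2 thus stands beside compound 1, with no separation that the measurement can resolve.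

Compound 3 `C/C(=N/O)c1ccc(OCC(=O)Nc2ccc(C(=O)/C=C/c3ccc(Cl)cc3)cc2)cc1` is unmeasured. The change is a group of 4 heavy atoms (2 carbon, 1 nitrogen, 1 oxygen; no ring) in place of a group of 3 heavy atoms (2 carbon, 1 oxygen; no ring), on an aromatic carbon, on an aromatic carbon of a six-membered aromatic ring of carbon only, para to a large group. Within the data shown here, no measured step touches the acetyl group, and the only step on record, a number 1 percentage points higher from compound 1 to compound 2 (within the scatter), changed a distant part of the molecule without moving the number beyond the scatter. The expected step is therefore no change at the digits printed from compound 2 to compound 3 (within the scatter), none beyond the scatter. For compound 3 the estimate in this assay is 43%, expected to fall between 25% and 60%.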

Compound 3, a percentage reported as inhibition, in the whole organism at one dose (the size of the read-out at that dose, not a potency): 39%
Compound 3: the middle estimate sits 4 percentage points above what was measured, and the stated range covers the measured number.
By their numbers in this assay, from the lowest: compounds 3, 1 and 2 (each within the scatter of the next).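

In this assay, among these compounds, the exchange of the acetyl group on the aromatic carbon gives a number 4 percentage points lower from compound 2 to compound 3 (within the scatter), so this is the first sign that the read-out does not separate these two groups at this position, even though the entering group has 1 hydrogen-bond donor and the acetyl group has 0. The wider change on the oxygen on a saturated carbon gives a number 3 percentage points lower from compound 1 to compound 3 (within the scatter), which leaves all three compounds unresolved at the one dose given. Nothing on record accounts for this result.

From the compounds shown here alone, it stays open whether an amine or a carboxylic acid on this aromatic carbon would move the number beyond the scatter. The same question stands for a longer chain in place of the acetyl group.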